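Cyano step from compound 1 to compound 4

The compounds below may be only part of what the source reports. "The series", "measured", "known", "first", "only" and "open" are said of these compounds alone.

All readings here come from a functional assay on MT4 cells (Homo sapiens) for cytotoxicity; on this read-out higher numbers stand for weaker inhibition and lower numbers for stronger inhibition. Compound 1 `N#Cc1c(N)cccc1S(=O)(=O)c1ccccc1` gives > 5000 nM, which is a limit and not a number. Its standing is therefore known only as a limit. Compound 2 `N#Cc1c(N)cccc1S(=O)(=O)c1ccccc1F` gives 57000 nM. Compound 3 `N#Cc1ccccc1S(=O)(=O)c1cccc(N)c1C#N` gives > 200000 nM, which is also a limit.

Compound 4 `N#Cc1cccc(S(=O)(=O)c2cccc(N)c2C#N)c1` is the open case, with this change from compound 1: cyano in place of hydrogen on an aromatic carbon. It is cyano in place of hydrogen on an aromatic carbon, meta to a large group.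

Among the compounds with values here, the nearest precedent is the same kind of exchange, a step that the two limits leave unreadable from compound 1 to compound 3, although compound 3 carries its cyano at another place than compound 4. The fluoro exchange offers no firmer guide, with a step that the limit leaves unreadable from compound 1 to compound 2. Within the data shown here, the only step with a readable bound is an at least 3.5-fold higher number from compound 2 to compound 3 (0.54 log units; beyond the scatter), so cyano in compound 3 goes with a higher number than fluoro in compound 2.

On that basis, compound 4 is expected to sit at high numbers, near compound 2 or beyond it, and may itself return only a limit. The expected change is a step that the limit leaves unreadable from compound 1 to compound 4, an estimate that rests on few data. Compound 4 is estimated at 100000 nM, with an expected range of 30000 nM to 300000 nM.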

Compound 4, half-maximal inhibitory concentration: > 200000 nM
Compound 4: only a limit was reported (the forecaster's own chance of this, stated with the estimate: 45%); middle value at least 2.0-fold (0.30 log units) from the limit.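

Within the data shown here, compound 4 and compound 1 both stand only as limits in this assay, so the step between them cannot be read and no new step follows. The compounds shown leave open whether cyano in place of hydrogen on an aromatic carbon shifts the read-out from compound 1 at all, and by how much.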